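Aminomethyl variants on the shared core: cytotoxicity working notes

A few compounds are considered here, and "the series" means these few. Any claim that something is new, unique, unknown or untested is made for them only; others in the source may bear on it.

Measured compounds:
compound 1 `COc1cc(Cc2cnc(/N=C3\C(=O)N(CN4CCCCC4C)c4ccc(Cl)cc43)nc2N)cc(OC)c1OC`: 97.3 ug/mL
compound 2 `CCn1cc(C(=O)O)c(=O)c2cc(F)c(N3CCN(CN4C(=O)/C(=N\c5ncc(Cc6cc(OC)c(OC)c(OC)c6)c(N)n5)c5cc(Cl)ccc54)C(C)C3)c(F)c21`: 36.9 ug/mL
compound 3 `COc1cc(Cc2cnc(/N=C3\C(=O)N(CN(Cc4ccccc4)Cc4ccccc4)c4ccc(Cl)cc43)nc2N)cc(OC)c1OC`: 44.1 ug/mL

All three were run in an ADME assay on MT4 cells (Homo sapiens) for cytotoxicity, read by MTT assay, with a stated time of 5 days; on this read-out higher numbers stand for lower toxicity in this test and lower numbers for higher toxicity in this test. Compound 1 gives the highest of the three numbers, so it reads as the least toxic of the set in this assay. The nearest number belongs to compound 3, whose value sits beyond the usual scatter below that of compound 1; the furthest belongs to compound 2, also beyond the scatter. Going by the values given here, no pair here differs in only one place, so no single-point step can be read from the measured set.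

Compound 4 `CCN(CC)CN1C(=O)/C(=N\c2ncc(Cc3cc(OC)c(OC)c(OC)c3)c(N)n2)c2cc(Cl)ccc21` has not yet been measured. It differs from compound 1 by diethylamino in place of 2-methylpiperidin-1-yl on a saturated chain carbon bound to an amide-type nitrogen in a ring. The change stays on the same saturated chain carbon bound to the amide-type nitrogen in a ring and trades a ring-bearing amine for an open-chain one.

Among the compounds with values here, with no measured single-point step to lean on, the expectation for this assay is a small move downward or none beyond the scatter, a 1.4-fold lower number from compound 1 to compound 4 (0.14 log units; within the scatter). Compound 4 is accordingly estimated at 70 ug/mL, with a range from 35 ug/mL to 140 ug/mL.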

Compound 4, half-maximal cytotoxic concentration: 79.1 ug/mL
The estimate for compound 4 lay 1.1-fold (0.05 log units) below the measured number, within the range that was stated.
By their numbers in this assay, from the lowest: compounds 2, 3, 4 and 1 (each within the scatter of the next, the first and the last beyond it).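

In this assay the set now has its first single-point step, a 1.2-fold lower number from compound 1 to compound 4 (0.09 log units; within the scatter), and it lies within the scatter: on a saturated chain carbon bound to an amide-type nitrogen in a ring, diethylamino in place of 2-methylpiperidin-1-yl leaves no readable change. For this one pair, then, the ring-bearing amine and the open-chain amine cannot be told apart on this read-out, and the ring of 2-methylpiperidin-1-yl is not required to keep the number where it stands. Nothing measured here accounts for the two amines reading alike, and the step stands as an observation only.

Still open, on these data alone, is whether this tolerance reaches other amines at the same place, such as dimethylamino, unsubstituted piperidin-1-yl or morpholin-4-yl, or whether one of these would move the number beyond the scatter. Also open, as far as these compounds go, is whether a hydroxyethyl group on the amine nitrogen, or a longer chain between that nitrogen and the amide-type nitrogen in a ring, would leave this assay just as unmoved.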